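Replacing a pyridinyl ring with a trifluoromethoxyphenyl ring

This account rests on a few compounds, and the source may have more. Where it says the series, first, only, none or still open, it means among the compounds named here.

Compound 1, `COc1nc(C2CCOCC2)ccc1[C@@H](c1ccccc1)[C@@](O)(CCN(C)C)c1cccc2ccccc12`: > 50 ug/mL, a limit of the assay.
Compound 2, `COc1nc(C(C)(C)C)ccc1[C@@H](c1ccccc1)[C@@](O)(CCN(C)C)c1cccc2ccccc12`: 27.6 ug/mL.
Compound 3, `COc1nc(-c2ccncc2)ccc1[C@@H](c1ccccc1)[C@@](O)(CCN(C)C)c1cccc2ccccc12`: > 50 ug/mL, a limit of the assay.

These values come from a toxicity assay on Vero cells (Chlorocebus sabaeus) for cytotoxicity; on this read-out lower numbers stand for higher toxicity in this test and higher numbers for lower toxicity in this test. Compound 3 stands at the limit of > 50 ug/mL in this assay, at which 2 of the 3 values shown sit, so only a floor is known for it. Compound 4, `COc1nc(-c2ccc(OC(F)(F)F)cc2)ccc1[C@@H](c1ccccc1)[C@@](O)(CCN(C)C)c1cccc2ccccc12`, differs from compound 3 in one place: 4-(trifluoromethoxy)phenyl in place of pyridin-4-yl on an aromatic carbon. The two measured steps that touch compound 3 are an at least 1.8-fold higher number from compound 2 to compound 3 (0.25 log units; that floor lies within the scatter) and a step that the two limits leave unreadable from compound 1 to compound 3; neither involves a phenyl ring, and both rest on a limit, so they give little guidance. Compound 4 is expected to give 35 ug/mL, between 15 ug/mL and 60 ug/mL. That estimate means an at least 1.4-fold lower number from compound 3 to compound 4 (0.15 log units; that floor lies within the scatter), a step that the limit of compound 3 leaves uncertain.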

Compound 4, half-maximal cytotoxic concentration: > 50 ug/mL
Compound 4: a limit, no number; the forecaster's own chance of this, stated with the estimate: 40%; middle value at least 1.4-fold (0.15 log units) from the limit.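

In this assay compound 4 gives > 50 ug/mL, a limit of the assay. Among these compounds, with this result, a carbon-only aromatic ring at this position joins the compounds without a measured number, and the one readable step is an at least 1.8-fold higher number from compound 2 to compound 4 (0.25 log units; that floor lies within the scatter). The steps to compound 4 from compound 1 and compound 3 join two limits and cannot be read: the limit of > 50 ug/mL in this assay, at which 3 of the 4 values shown sit.

As far as these compounds go, how compound 1, compound 3 and compound 4 rank against one another stays open. Also open, from the compounds shown here alone, is whether an amine or a carboxylic acid at this position would give a measured number.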